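This account rests on a few compounds, and the source may have more. Where it says the series, first, only, none or still open, it means among the compounds named here.

Compound 1 `O=C1CC(c2ccccc2F)C(=O)N1CN1CCN(c2ccc(F)cc2)CC1`: 30 mg/kg
Compound 2 `O=C1CC(c2ccccc2Br)C(=O)N1CN1CCN(c2ccccc2)CC1`: 100 mg/kg

Both compounds were tested in a functional assay on the whole organism (strain CF-1 albino) with Mus musculus as the target, with a stated time of 4 h; a lower number here means that less compound is needed, a higher number that more compound is needed for the effect. Compound 2 gives the highest of the two numbers, with 100 mg/kg, and compound 1 stands at 30 mg/kg, a difference that lies beyond the scatter. Within the data shown here, the two compounds differ in two places at once, so no single step between them can be read from these numbers.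

Compound 3 `O=C1CC(c2ccccc2Br)C(=O)N1CN1CCN(c2ccc(F)cc2)CC1` has not yet been measured in this assay . It is reached from compound 2 by one change, (fluoro in place of hydrogen on an aromatic carbon). Compound 1 carries the same fluoro group and gives the lower number, but its other difference from compound 2 leaves the contribution of the fluoro alone unknown. A modest move toward a lower number is expected from compound 2 to compound 3, with a 2.0-fold lower number from compound 2 to compound 3 (0.30 log units; within the scatter), though a result within the scatter would not surprise. Compound 3 is thus estimated at 50 mg/kg, in a range from 20 mg/kg to 150 mg/kg.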

Compound 3, minimum effective dose: 100 mg/kg
Estimate against measurement, compound 3: 2.0-fold (0.30 log units) below; the measured number falls inside the stated range.
By their numbers in this assay, from the lowest: compound 1; then compounds 2 and 3 (each within the scatter of the next).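

In this assay, the phenyl to 4-fluorophenyl change gives no change at the digits printed from compound 2 to compound 3 (within the scatter), so with bromo on the other aromatic ring, this position shows no response to fluoro in place of hydrogen. Bromo in place of fluoro on an aromatic carbon, with 4-fluorophenyl held constant, gives a 3.3-fold higher number from compound 1 to compound 3 (0.52 log units; beyond the scatter), which places a step beyond the scatter at the halogen rather than at the fluoro of the 4-fluorophenyl group. No measurement shown accounts for the size of either step.

The compounds shown leave open how a chloro or a methoxy group would read in place of that bromo or fluoro, and how an amine would read in place of the fluoro of the 4-fluorophenyl group. From the compounds shown here alone, whether the halogen step holds with plain phenyl also remains open.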